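Swapping the carboxy of compound 3 for cyclohexyl

A few compounds are considered here, and "the series" means these few. Any claim that something is new, unique, unknown or untested is made for them only; others in the source may bear on it.

In a physicochemical assay for activation, with a stated time of 60 min (a higher number here means that more compound is needed for the effect, a lower number that less compound is needed), compound 3 (`O=C1NC(=O)/C(=C\c2ccc(C(=O)O)cc2)C2=C1CCCC2`) gives 53000 nM as the highest of three numbers, while compound 2 (`O=C1NC(=O)/C(=C\c2ccco2)C2=C1CCCC2`) gives 18000 nM and compound 1 (`O=C1NC(=O)/C(=C\c2ccc(Cl)cc2)C2=C1CCCC2`) gives 500 nM with chloro where compound 3 has carboxy. Within the data shown here, compound 4 (`O=C1NC(=O)/C(=C\c2ccc(C3CCCCC3)cc2)C2=C1CCCC2`) differs from compound 3 by cyclohexyl in place of carboxy on an aromatic carbon and has no measurement yet. Among the measured compounds shown here, the one measured step at this place is a 110-fold higher number from compound 1 to compound 3 (2.03 log units; beyond the scatter) (large) and it brought in the carboxy. For the measured compounds named here, no cyclohexyl compound has been measured, so how much of that step comes back is uncertain. The expected step is a 35-fold lower number from compound 3 to compound 4 (1.55 log units; beyond the scatter) in this assay (a large one toward a lower number). For compound 4 the estimate is 1500 nM with an expected range from 300 nM to 8000 nM in this assay.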

Compound 4, half-maximal effective concentration: 121000 nM
Compound 4: the middle estimate sits 81-fold (1.91 log units) below what was measured; measured number above the stated range.
By their numbers in this assay, from the lowest: compound 1; then compound 2; then compound 3; then compound 4.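

In this assay removing the carboxy does not by itself bring the number back down: cyclohexyl, with 0 hydrogen-bond donors and 0 hydrogen-bond acceptors, still gives a higher number (a 2.3-fold higher number from compound 3 to compound 4 (0.36 log units; beyond the scatter)). Measured against chloro, the change is larger still (a 240-fold higher number from compound 1 to compound 4 (2.38 log units; beyond the scatter)), so two very different groups at this place both stand far from chloro. No available evidence bears on the reason for this result. From the compounds shown here alone, whether bromo, methyl or methoxy at this place would stay close to compound 1 remains open.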